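The source may report more compounds than this note shows. Statements on the series, on what has been measured and on what is new or still open speak of the compounds shown alone.

Measured in a functional assay on DU-145 cells (Homo sapiens) for inhibition, read by trypan blue exclusion, with a stated time of 96 h; on this read-out higher numbers stand for weaker inhibition of growth and lower numbers for stronger inhibition of growth:
- compound 1 `Cc1ccc(S(=O)(=O)/C(=C/c2ccc(F)cc2F)C(=O)c2ccc(Br)cc2)cc1`: > 100000 nM
- compound 2 `O=C(/C(=C\c1c[nH]c2ccccc12)S(=O)(=O)c1ccc(Br)cc1)c1ccc(Br)cc1`: 25000 nM

The entry for compound 1 is a limit. Among the measured compounds shown here, compound 2 therefore holds the only number so far. Compound 3 `Cc1ccc(S(=O)(=O)/C(=C/c2c[nH]c3ccccc23)C(=O)c2ccc(Br)cc2)cc1` differs from compound 2 by methyl in place of bromo on an aromatic carbon, turning (4-bromophenyl)sulfonyl into (4-methylphenyl)sulfonyl. For the measured compounds named here, no measured step covers this change. In this assay, no shift beyond the scatter is expected, in either direction. The expected step, no change at the digits printed from compound 2 to compound 3 (within the scatter), is an estimate only. For compound 3 the estimated value is 25000 nM, with an expected range of 8000 nM to 80000 nM.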

Compound 3, concentration for 50% growth inhibition: 10000 nM
Compound 3: the middle estimate sits 2.5-fold (0.40 log units) above what was measured, within the range that was stated.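

In this assay methyl in place of bromo in the (4-methylphenyl)sulfonyl group gives a 2.5-fold lower number from compound 2 to compound 3 (0.40 log units; beyond the scatter) and so shows that this position affects the read-out. With that group held constant, 1H-indol-3-yl in place of 2,4-difluorophenyl gives an at least 10-fold lower number from compound 1 to compound 3 (1.00 log units; beyond the scatter) on the same chain carbon. Compound 1 carries a limit, so that step has one bound only: the limit of > 100000 nM in this assay, at which 1 of the 3 values shown sits.

On these data alone, whether an amine or a methoxy group at this position would move the number further remains open. So does whether the 4-bromophenyl group on the carbonyl responds to the same change.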